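The source may hold more compounds than are shown below. What is called first, only, known or untested is meant among the compounds shown, and "the series" means these compounds.

This study follows two measured compounds built on a shared core and asks what a third, not yet tested, would show. Compound 1 `C=C1C[C@]23C[C@@]1(O)CC[C@H]2c1cc2c(C(=O)O)coc2c(C)c1[C@@H]3C(=O)O` carries two free acid groups. In a functional assay on CA46 cells (Homo sapiens) for cytotoxicity, read by luminescence and CellTiter-Glo, with a stated time of 24 h (a lower number here means a stronger inhibitor, a higher number a weaker inhibitor), compound 1 gives only a limit, > 10000 nM, and not a number. Compound 2 `C=C1C[C@]23C[C@@]1(O)CC[C@H]2c1cc(Br)c(O/C=C/C(=O)OC)c(C)c1[C@@H]3C(=O)OC` carries two methyl esters and a bromo group on its aromatic ring. In this assay compound 2 also gives only a limit, > 10000 nM, and not a number. Compound 2 thus stands where compound 1 stands, namely at the limit of > 10000 nM in this assay, at which 2 of the 2 values shown sit; nothing can be read about which of the two is the stronger.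

Compound 3 `C=C1C[C@]23C[C@@]1(O)CC[C@H]2c1ccc(O/C=C/C(=O)OC)c(C)c1[C@@H]3C(=O)OC` differs from compound 2 in one place: hydrogen in place of bromo on an aromatic carbon. Within the data shown here, no step between measured compounds is known here, so the data give no size for such a change. Because compound 2 sits at the limit of > 10000 nM in this assay, at which 2 of the 2 values shown sit, the expected step that the limit leaves unreadable from compound 2 to compound 3 is given no direction beyond the scatter, and it is estimated that compound 3 will most likely again be reported as a limit. Compound 3 is expected to give about 20000 nM in this assay, within a range from 3000 nM to 100000 nM.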

Compound 3, half-maximal inhibitory concentration: > 10000 nM
Compound 3 was reported as a limit; the forecaster's own chance of this, stated with the estimate: 80%; the middle value does not contradict the limit.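

Compound 2 and compound 3 are both reported only as limits and not as numbers, so no step between them can be read in this assay: the limit of > 10000 nM in this assay, at which 3 of the 3 values shown sit.

The compounds shown leave open how large the change from bromo to hydrogen on the aromatic carbon is, and whether any compound on the shared core gives a measurable number in this assay.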